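The source may hold more compounds than are shown below. What is called first, only, known or untested is meant among the compounds shown, and "the series" means these compounds.

Measured compounds:
compound 1 `COc1ccccc1-c1cc(C2CCNC2)ccc1Cl` — 410 nM
compound 2 `COc1ccccc1-c1cc(C2CCN(C)C2)ccc1Cl` — 12 nM

Within the pair measured in an assay on isolated protein for binding affinity to 5-hydroxytryptamine receptor 1B (Homo sapiens) (a lower number here means a stronger inhibitor, a higher number a weaker inhibitor), compound 1 gives the higher of the two numbers; the one recorded step is a 34-fold lower number from compound 1 to compound 2 (1.53 log units; beyond the scatter), the only change there being methyl in place of hydrogen on an amine nitrogen in a ring.

Compound 3 `CCNCc1ccc(Cl)c(-c2ccccc2OC)c1` changes compound 1 differently: (ethylamino)methyl in place of pyrrolidin-3-yl on an aromatic carbon. The ring of pyrrolidin-3-yl is lost and the amine nitrogen now carries an ethyl group and sits outside any ring. Among the compounds with values here, no measured step covers such a ring opening, so the measured step from compound 1 to compound 2 bears on it only in that the amine nitrogen gains an alkyl group, and that case kept the ring. Within the data shown here, compound 3 remains a secondary amine like compound 1, and the loss of the ring has no precedent, so no confident shift is expected in this assay beyond the scatter, with some lean toward a weaker value.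

Compound 3 is therefore estimated at 800 nM, range 150 nM to 4000 nM; the expected step is a 2.0-fold higher number from compound 1 to compound 3 (0.29 log units; within the scatter).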

Compound 3, inhibition constant: 210 nM
Beside the measured number, compound 3's estimate is 3.8-fold (0.58 log units) above it; the measured number falls inside the stated range.
By their numbers in this assay, from the lowest: compound 2; then compounds 3 and 1 (each within the scatter of the next).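

In this assay, (ethylamino)methyl in place of pyrrolidin-3-yl on this aromatic carbon gives a 2.0-fold lower number from compound 1 to compound 3 (0.29 log units; within the scatter) and so leaves the two secondary amines, compound 1 and compound 3, unseparated: at the level of compound 1, the ring of pyrrolidin-3-yl is not needed at this position. Measured against 1-methylpyrrolidin-3-yl, the same open-chain group gives an 18-fold higher number from compound 2 to compound 3 (1.24 log units; beyond the scatter) and so compound 3 does not recover the gain seen on methylating the ring nitrogen (a 34-fold lower number from compound 1 to compound 2 (1.53 log units; beyond the scatter)), which means an alkyl group on the amine nitrogen does not by itself bring the number down to that of compound 2, with compound 3 going against any such reading. Nothing available explains either step or the gap between the ring and open-chain forms.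

Going by these compounds, what stays open is whether a tertiary open-chain amine, such as (N-ethyl-N-methylamino)methyl or (dimethylamino)methyl, would match compound 2, which would separate the substitution of the nitrogen from the presence of the ring. Equally open, on these data alone, is how a longer chain on the nitrogen, such as propyl, or a larger ring, such as 1-methylpiperidin-3-yl, would fare at this position.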